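This account rests on a few compounds, and the source may have more. Where it says the series, first, only, none or still open, it means among the compounds named here.

Working notes on the benzyl series

The shared core of compound 1 `CC1(C)c2[nH]nc(NC(=O)c3ccccc3)c2CN1Cc1cccc(Cl)c1` carries a benzyl group on the ring amine; in an assay on Sf21 cells for inhibition of high affinity nerve growth factor receptor (Homo sapiens), read by HTRF, with a stated time of 30 min, in the presence of a further agent that is not named here (a lower number here means a stronger inhibitor, a higher number a weaker inhibitor), compound 1 gives 670 nM. Compound 2 `CC1(C)c2[nH]nc(NC(=O)c3ccccc3)c2CN1Cc1cc(F)ccc1F` gives 480 nM in this assay and compound 3 `CC1(C)c2[nH]nc(NC(=O)c3ccccc3)c2CN1Cc1ccc(F)c(F)c1` gives 680 nM. The three sit together: a 1.0-fold higher number from compound 1 to compound 3 (0.01 log units; within the scatter) and a 1.4-fold higher number from compound 2 to compound 3 (0.15 log units; within the scatter), so compound 3 is not separated from either neighbour. Compound 4 `Cc1ccc(CN2Cc3c(NC(=O)c4ccccc4)n[nH]c3C2(C)C)cc1F` has not been measured; it differs from compound 3 by methyl in place of fluoro on an aromatic carbon. Within the data shown here, no measured step exchanges fluoro for methyl, and the benzyl variations seen so far, including a 1.4-fold lower number from compound 1 to compound 2 (0.14 log units; within the scatter), all stay within the scatter. The expected step is therefore a 1.0-fold lower number from compound 3 to compound 4 (0.02 log units; within the scatter), no change beyond the scatter. Compound 4 is estimated at 650 nM in this assay, in the range 300 nM to 1400 nM.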

Compound 4, half-maximal inhibitory concentration: 940 nM
For compound 4 the middle estimate is 1.4-fold (0.16 log units) below the measured one; the measured number falls inside the stated range.
By their numbers in this assay, from the lowest: compounds 2, 1, 3 and 4 (each within the scatter of the next).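

Methyl in place of fluoro on this aromatic carbon, para to a large group, stays within the scatter (a 1.4-fold higher number from compound 3 to compound 4 (0.14 log units; within the scatter)), the first reading for this exchange. The comparisons with the other benzyl groups also stay within it (a 1.4-fold higher number from compound 1 to compound 4 (0.15 log units; within the scatter); a 2.0-fold higher number from compound 2 to compound 4 (0.29 log units; within the scatter)), so the four compounds remain unseparated. No supporting data bear on this result.

The compounds shown leave open whether an amine, a carboxylic acid or a longer chain on this carbon would separate from fluoro and methyl. From the compounds shown here alone, whether the same exchange reads alike with another benzyl pattern also stays open.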